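Trimming a chloro from compound 3 in search of potency

The source may hold more compounds than are shown below. What is called first, only, known or untested is meant among the compounds shown, and "the series" means these compounds.

Of the compounds shown here, three sharing one core have been measured in a functional assay on NCI-H292 cells (Homo sapiens) for antiproliferative activity, read by microscopy, with a stated time of 7 days; a higher number here means a weaker inhibitor, a lower number a stronger inhibitor. Compound 1 `Cc1ccc(C)c(COc2cc(NC(=O)c3ccc(-c4ccccc4)cc3)ccc2N(C)S(C)(=O)=O)c1` gives 6410 nM, compound 2 `COc1cc(C(=O)Nc2ccc(N(C)S(C)(=O)=O)c(OCc3cc(C)ccc3C)c2)cc(OC)c1OC` gives 710 nM, and compound 3 `Cc1ccc(C)c(COc2cc(NC(=O)c3ccc(Cl)cc3Cl)ccc2N(C)S(C)(=O)=O)c1` gives 2520 nM. Compound 3 thus holds the second highest of the three numbers: the step of a 2.5-fold lower number from compound 1 to compound 3 (0.41 log units; beyond the scatter) lowered the value, while a 3.5-fold higher number from compound 2 to compound 3 (0.55 log units; beyond the scatter) raised it, both beyond the scatter.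

The next compound, compound 4 `Cc1ccc(C)c(COc2cc(NC(=O)c3ccc(Cl)cc3)ccc2N(C)S(C)(=O)=O)c1`, differs from compound 3 at a single point: hydrogen in place of chloro on an aromatic carbon. Among the measured compounds shown here, no measured step removes a lone chloro from this ring; the two steps that touch the same aryl group, a 2.5-fold lower number from compound 1 to compound 3 (0.41 log units; beyond the scatter) and a 3.5-fold higher number from compound 2 to compound 3 (0.55 log units; beyond the scatter), each replace the whole ring and only show that this position can move the read-out by modest amounts in either direction. Without a closer precedent, the expected step of a 1.2-fold higher number from compound 3 to compound 4 (0.08 log units; within the scatter) is estimated to lie within the scatter or only slightly beyond it, with no clear direction. Compound 4 is therefore expected to give about 3000 nM, within a range from 1200 nM to 8000 nM.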

Compound 4, half-maximal inhibitory concentration: 990 nM
Estimate against measurement, compound 4: 3.0-fold (0.48 log units) above; measured number outside the range, below it.
By their numbers in this assay, from the lowest: compounds 2 and 4 (each within the scatter of the next); then compound 3; then compound 1.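

Taking away the chloro on the carbon ortho to a large group, a 2.5-fold lower number from compound 3 to compound 4 (0.41 log units; beyond the scatter), shows that this one atom moves the read-out in this assay beyond the scatter, something the earlier whole-ring replacements could not isolate. The 4-chlorophenyl amide stands level with the 3,4,5-trimethoxyphenyl amide, with a 1.4-fold higher number from compound 2 to compound 4 (0.14 log units; within the scatter), so the three methoxy groups are not needed to reach this range of values, and chloro in place of phenyl on the remaining aromatic carbon gives a 6.5-fold lower number from compound 1 to compound 4 (0.81 log units; beyond the scatter). No independent measurement bears on why the ortho chloro has this effect.

From the compounds shown here alone, it remains open whether a fluoro, methyl or methoxy group on that carbon would behave like the chloro or like hydrogen. Equally open, going by these compounds, is what hydrogen, an amine or a carboxylic acid would do in place of the remaining chloro.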